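Ester side chain to allylic alcohol on a tetrahydropyran

The source may report more compounds than this note shows. Statements on the series, on what has been measured and on what is new or still open speak of the compounds shown alone.

Two measured compounds share a core: compound 1 `COC(=O)/C=C/C[C@H]1OCCC[C@@H]1O[Si](C)(C)C(C)(C)C` and compound 2 `COC(=O)/C=C/[C@H]1OCCC[C@@H]1O[Si](C)(C)C(C)(C)C`. In a functional assay on MCF7S cells (Homo sapiens) (on this read-out higher numbers stand for weaker inhibition of growth and lower numbers for stronger inhibition of growth), compound 1 gives 18000 nM, the lowest of the two numbers, and compound 2 gives 24000 nM. The step of a 1.3-fold higher number from compound 1 to compound 2 (0.12 log units; within the scatter) shows that shortening the ester-bearing side chain by one carbon left the read-out essentially where it was.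

Compound 3 `CC(C)(C)[Si](C)(C)O[C@H]1CCCO[C@@H]1/C=C\CO` is not yet measured. It differs from compound 1 as follows: 3-hydroxyprop-1-en-1-yl in place of 3-(methoxycarbonyl)prop-2-en-1-yl on a saturated ring carbon. For the measured compounds named here, the only measured step that bears on this change is the one from compound 1 to compound 2, which also altered the chain on that same ring carbon and stayed within the scatter. Going by the values given here, no measured pair covers the exchange of the methyl ester for a hydroxyl group, so the evidence is thin. On that basis the expected step of a 1.1-fold higher number from compound 1 to compound 3 (0.05 log units; within the scatter) in this assay is small, with no clear direction beyond the scatter. Compound 3 is therefore estimated at about 20000 nM, with a plausible range from 6000 nM to 70000 nM.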

Compound 3, concentration for 50% growth inhibition: 6400 nM
For compound 3 the middle estimate is 3.1-fold (0.49 log units) above the measured one; the range from low to high includes it.
By their numbers in this assay, from the lowest: compound 3; then compounds 1 and 2 (each within the scatter of the next).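

In this assay, putting 3-hydroxyprop-1-en-1-yl on this saturated ring carbon gives a 2.8-fold lower number from compound 1 to compound 3 (0.45 log units; beyond the scatter) when it replaces 3-(methoxycarbonyl)prop-2-en-1-yl, and a 3.8-fold lower number from compound 2 to compound 3 (0.57 log units; beyond the scatter) when it replaces 2-(methoxycarbonyl)ethenyl. The earlier change at this carbon, a 1.3-fold higher number from compound 1 to compound 2 (0.12 log units; within the scatter) and so within the scatter, altered only the chain between the ring and the ester, whereas these two steps show that the read-out can move at this position, here towards stronger inhibition of growth, though only modestly. This exchange removes the methyl ester and brings in a hydroxyl group, so it is the first change shown that alters the end of the chain as well as its length.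

The compounds shown cannot separate the loss of the ester from the arrival of the hydroxyl group, and a carboxylic acid, a methyl ether or an amine at the end of the same chain would help to tell these apart. Whether a longer chain ending in a hydroxyl group would follow compound 3 also stays open, and no measurement given here explains why this exchange moves the read-out.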